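A Crowded Phenyl Arm Replaces the Chlorophenyl Group

The source may hold more compounds than are shown below. What is called first, only, known or untested is meant among the compounds shown, and "the series" means these compounds.

Of the compounds shown here, two have so far been tested in an assay on isolated protein for inhibition of Maltase-glucoamylase (Homo sapiens), with a stated time of 15 min; on this read-out lower numbers stand for stronger inhibition and higher numbers for weaker inhibition. Compound 1 `O=C(N/N=C/c1ccccc1)c1ccc(-c2nc3ccccc3s2)cc1` gives 8050 nM, and compound 2 `O=C(N/N=C/c1ccc(Cl)cc1)c1ccc(-c2nc3ccccc3s2)cc1` gives 5310 nM. The step of a 1.5-fold lower number from compound 1 to compound 2 (0.18 log units; within the scatter) shows that these two numbers cannot be told apart. Compound 2 holds the lower of the two numbers, yet its gap to compound 1 lies within the scatter, so neither compound can be called the stronger inhibitor.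

Compound 3 `COc1ccc(/C=N/NC(=O)c2ccc(-c3nc4ccccc4s3)cc2)c(I)c1O` is built from compound 2 by the change (3-hydroxy-2-iodo-4-methoxyphenyl in place of 4-chlorophenyl on a carbon with a double bond to nitrogen). Among the measured compounds shown here, the only measured step, from compound 1 to compound 2, swapped hydrogen for chlorine on the same ring and stayed within the scatter; it is a far smaller change than the present one, which removes the chlorine and brings in a hydroxy, a methoxy and an iodo group at once. Nothing measured shows how these three groups together affect this assay, so the expectation rests on that single quiet step. Compound 3 is therefore expected to stay near its parent, with a 1.2-fold lower number from compound 2 to compound 3 (0.07 log units; within the scatter). Compound 3 is estimated at 4500 nM in this assay, with a range from 1500 nM to 13000 nM.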

Compound 3, half-maximal inhibitory concentration: 44800 nM
The estimate for compound 3 lay 10-fold (1.00 log units) below the measured number, and the stated range ends below it.
By their numbers in this assay, from the lowest: compounds 2 and 1 (each within the scatter of the next); then compound 3.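

In this assay, the group on the carbon with a double bond to nitrogen clearly matters: 3-hydroxy-2-iodo-4-methoxyphenyl in place of 4-chlorophenyl gives an 8.4-fold higher number from compound 2 to compound 3 (0.93 log units; beyond the scatter), whereas the earlier swap of hydrogen for chloro on that ring stayed within the scatter. The same group in place of plain phenyl gives a 5.6-fold higher number from compound 1 to compound 3 (0.75 log units; beyond the scatter), so the change counts against both earlier compounds, and compound 3 is the weakest inhibitor of the three. Nothing available accounts for this rise in the number.

On these data alone, the hydroxy, methoxy and iodo groups all enter in one step, so it remains open which of them carries the change, and whether any one of them alone would shift the number at all. Also open, as far as these compounds go, is how the assay would respond to a quite different group on the phenyl ring, such as an amine or a carboxylic acid, and whether any group there can bring the number clearly below that of compound 2.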